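Swapping a Large Side Group for a Small One

This account rests on a few compounds, and the source may have more. Where it says the series, first, only, none or still open, it means among the compounds named here.

Of the compounds shown here, three sharing one core have been measured in an ADME assay (liver) for metabolic stability, with Liver microsome (Rattus norvegicus) as the target, using microsomes and NADPH, with a stated time of 30 min; on this read-out lower numbers stand for slow clearance and higher numbers for fast clearance. Compound 1 `CC#C[C@H]1CN(S(=O)(=O)c2ccc(N)nc2)CCN1c1ccc(C(O)(CC#N)C(F)(F)F)cc1` gives 57 mL.min-1.g-1, the highest of the three numbers. Compound 2 `CC#C[C@H]1CN(S(=O)(=O)c2ccc(N)nc2)CCN1c1ccc(S(=O)(=O)NC)cn1` gives 42 mL.min-1.g-1, a number within the usual scatter of that for compound 1, so no order between the two can be read from these figures. Compound 3 `CC#C[C@H]1CN(S(=O)(=O)c2ccc(N)nc2)CCN1c1ncc(C(O)(C(F)(F)F)C(F)(F)F)cn1` gives 28 mL.min-1.g-1, which lies beyond the scatter below compound 1 and is therefore the only clear difference among the three.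

Going by the values given here, the next compound, compound 4 `CC#C[C@H]1CN(S(=O)(=O)c2ccc(N)nc2)CCN1c1ccc(S(C)(=N)=O)cc1`, keeps the core of compound 1 and changes only one group. The difference, (a group of 4 heavy atoms (1 carbon, 1 nitrogen, 1 oxygen, 1 sulfur; no ring) in place of a group of 9 heavy atoms (4 carbon, 1 nitrogen, 1 oxygen, 3 fluorine; no ring), on an aromatic carbon), is described in the words given with it. Because compound 1 stands at 57 mL.min-1.g-1 and compound 2, which also carries a small group of one carbon, one nitrogen, one oxygen and one sulfur on its ring, stands at 42 mL.min-1.g-1, a small move downward is the natural expectation here rather than a large one.

The step of a 1.6-fold lower number from compound 1 to compound 4 (0.21 log units; within the scatter) is expected to be a modest decrease, close to the edge of the usual scatter.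

Compound 4 is estimated to give 35 mL.min-1.g-1, with a likely range from 15 mL.min-1.g-1 to 80 mL.min-1.g-1.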

Compound 4, intrinsic clearance in microsomes: < 14 mL.min-1.g-1
Compound 4 gave a limit, no number (the forecaster's own chance of this, stated with the estimate: 5%); middle value at least 2.5-fold (0.39 log units) away from the limit.
By their numbers in this assay, from the lowest: compounds 3, 2 and 1 (each within the scatter of the next, the first and the last beyond it). At a limit, below all of these: compound 4.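

Exchanging the large side group for the small one on this aromatic carbon, para to a large group, gives an at least 4.0-fold lower number from compound 1 to compound 4 (0.60 log units; beyond the scatter) in this assay, so this single change is enough to move the read-out beyond the scatter. The two groups carry the same count of hydrogen-bond donors and the same count of acceptors, so the step comes with a change in group size and atom make-up, not in those counts. Compound 4 now sits at the end of the measurable range, and its result is a limit of the assay, not a number: the limit of < 14 mL.min-1.g-1 in this assay, at which 1 of the 4 values shown sits.

As far as these compounds go, whether the step follows the smaller size of the entering group or the sulfur it carries stays open; an amine or a methoxy group on this aromatic carbon would help to separate the two. From the compounds shown here alone, how much further the true value of compound 4 lies past its limit also remains unknown.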